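Methoxy on the aromatic ring of compound 1

The source may hold more compounds than are shown below. What is called first, only, known or untested is meant among the compounds shown, and "the series" means these compounds.

Among the measured compounds shown here, compound 1 `CC(C)(C)OC(=O)/C=C1/C(=O)Nc2ccccc21` is tested in a functional assay on HL-60 cells (Homo sapiens) for inhibition, read by CCK-8 assay, with a stated time of 72 h, tested at 20 uM (a lower number here means less inhibition of growth, a higher number more inhibition of growth at the concentration tested), and gives 94.5%, the second highest of the three numbers known so far. Its nearest neighbour is compound 3 `CN1C(=O)/C(=C/C(=O)OC(C)(C)C)c2ccccc21`, which gives 94.7%; the change a number 0.2 percentage points higher from compound 1 to compound 3 (within the scatter) is a methyl in place of hydrogen on an amide-type nitrogen in a ring. The furthest is compound 2 `CC(C)(C)OC(=O)/C=C1/C(=O)N(Cc2ccccc2)c2ccccc21`, which gives 91.7%; here a number 2.8 percentage points lower from compound 1 to compound 2 (within the scatter) comes with a benzyl in place of hydrogen on that same nitrogen. Between the two substituted compounds, a number 3 percentage points higher from compound 2 to compound 3 (within the scatter).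

Compound 4 `COc1ccc2c(c1)/C(=C\C(=O)OC(C)(C)C)C(=O)N2` differs from compound 1 in another part of the shared core: methoxy in place of hydrogen on an aromatic carbon. For the measured compounds named here, none of the measured steps touches an aromatic carbon, so no step bears directly on this change. All three measured steps were within the scatter, and all three compounds inhibit growth to nearly the same extent, so no step beyond the scatter is expected in this assay. Compound 4 is therefore estimated at 93%, between 80% and 98%, which means an expected step of a number 1.5 percentage points lower from compound 1 to compound 4 (within the scatter).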

Compound 4, percent growth inhibition at one concentration: 94.2%
Compound 4: the middle estimate sits 1.2 percentage points below what was measured; low and high end bracket the measured number.
By their numbers in this assay, from the lowest: compounds 2, 4, 1 and 3 (each within the scatter of the next).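

Among the compounds shown here, compound 4 brings the first change on the aromatic ring, as every earlier step sat on the amide-type nitrogen. Methoxy in place of hydrogen on this aromatic carbon gives a number 0.3 percentage points lower from compound 1 to compound 4 (within the scatter), so in this assay this position carries a methoxy with no step beyond the scatter. That matches what the methyl and benzyl groups on the nitrogen showed, now at a second place on the shared core, but no measurement shown offers an explanation for this result.

Still open, as far as these compounds go, is whether a different group on this aromatic carbon, such as an amine, a carboxylic acid or a longer alkoxy chain, would give a step beyond the scatter. Also open, from the compounds shown here alone, is whether methoxy on another carbon of the same ring would read the same, and how compounds 1 and 4 would compare at lower concentrations.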